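The source may report more compounds than this note shows. Statements on the series, on what has been measured and on what is new or still open speak of the compounds shown alone.

Working notes on the series. Compound 1 `Cc1cccc(C(=O)Nc2ccc3c(c2)CC(CNS(C)(=O)=O)C3)c1-c1ccc(C(F)(F)F)cc1` gives 150 nM in an assay on isolated protein for inhibition of microsomal triglyceride transfer protein large subunit (Homo sapiens); on this read-out higher numbers stand for weaker inhibition and lower numbers for stronger inhibition. Compound 2 `Cc1cccc(C(=O)Nc2ccc3c(c2)CC(CNS(C)(=O)=O)C3)c1-c1ccc(Cl)cc1` gives 500 nM in this assay. The change between them is chloro in place of trifluoromethyl on an aromatic carbon, and the step is a 3.3-fold higher number from compound 1 to compound 2 (0.52 log units; beyond the scatter). Compound 3 `COC(=O)NC1CCc2ccc(NC(=O)c3cccc(C)c3-c3ccc(C(F)(F)F)cc3)cc2CC1`, built on a different core, gives 20 nM in this assay; the difference between the two cores is not broken down here, and compound 3 stands at the lowest number of the three measured compounds. Compound 4 `COC(=O)NC1CCc2ccc(NC(=O)c3cccc(C)c3-c3ccc(Cl)cc3)cc2CC1`, not yet measured, carries the same change on the core of compound 3: chloro in place of trifluoromethyl on an aromatic carbon, at the same place. Because compound 1 to compound 2 gave a 3.3-fold higher number from compound 1 to compound 2 (0.52 log units; beyond the scatter), a step of comparable size is expected from compound 3 to compound 4, namely a 3.3-fold higher number from compound 3 to compound 4 (0.51 log units; beyond the scatter). Compound 4 is thus estimated at 65 nM, likely between 30 nM and 150 nM.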

Compound 4, half-maximal inhibitory concentration: 80 nM
Compound 4: the middle estimate sits 1.2-fold (0.09 log units) below what was measured; the range from low to high includes it.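

On the core of compound 3, chloro in place of trifluoromethyl gives a 4.0-fold higher number from compound 3 to compound 4 (0.60 log units; beyond the scatter) in this assay. The change carries over from one core to the other at much the same size: the same change on two cores in this assay, a 3.3-fold higher number (0.52 log units; beyond the scatter) from compound 1 to compound 2 and a 4.0-fold higher number (0.60 log units; beyond the scatter) from compound 3 to compound 4, 1.2-fold (0.08 log units) apart, within the scatter of two such steps

This rests on one pair on each of two cores in a single assay, and it does not show that the step would hold on further cores or explain why the change has this size. The compounds shown leave open whether a methyl, a methoxy or a nitrile in the same place would also carry across the two cores. The contribution of the difference between the two cores also remains unresolved.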